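Trimming Three Methoxy Groups to One on the Ketone Aryl

The source may hold more compounds than are shown below. What is called first, only, known or untested is meant among the compounds shown, and "the series" means these compounds.

Compound 1 `COc1cc(-c2nnc3n2NC(c2ccco2)C(C(=O)c2ccccc2C)S3)cc(OC)c1OC`, compound 2 `COc1cc(C(=O)C2Sc3nnc(-c4cc(OC)c(OC)c(OC)c4)n3NC2c2ccco2)cc(OC)c1OC` and compound 3 `COc1cc(-c2nnc3n2NC(c2ccco2)C(C(=O)c2ccccc2F)S3)cc(OC)c1OC` share one core and differ only in the aryl group on the carbonyl. In a functional assay on HepG2 cells (Homo sapiens) for cytotoxicity, read by MTT assay, with a stated time of 48 h (on this read-out higher numbers stand for weaker inhibition and lower numbers for stronger inhibition), compound 1 gives 63000 nM. For compound 2 this assay reports only a limit, > 100000 nM. For compound 3 it likewise reports only a limit, > 100000 nM. Among the measured steps, an at least 1.5-fold higher number from compound 1 to compound 2 (0.20 log units; that floor lies within the scatter) and an at least 1.5-fold higher number from compound 1 to compound 3 (0.20 log units; that floor lies within the scatter) hold, while a step that the two limits leave unreadable from compound 2 to compound 3 because both values sit at the limit of > 100000 nM in this assay, at which 2 of the 3 values shown sit. Compound 4 `COc1cccc(C(=O)C2Sc3nnc(-c4cc(OC)c(OC)c(OC)c4)n3NC2c2ccco2)c1` differs from compound 2 by 3-methoxyphenyl in place of 3,4,5-trimethoxyphenyl on a carbonyl carbon. Among the measured compounds shown here, no measured step covers this change, and the nearest one, in which the trimethoxyphenyl entered, was small. Compound 4 is therefore expected to remain weak, a number no higher from compound 2 to compound 4 (the limit leaves the size open), with an estimate of 100000 nM (from 50000 nM to 300000 nM).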

Compound 4, half-maximal inhibitory concentration: > 100000 nM
Compound 4 ended at the assay's limit; the forecaster's own chance of this, stated with the estimate: 60%; the middle value lies on the limit itself.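

With the 3-methoxyphenyl on the carbonyl carbon, compound 4 also gives only a limit, so going from the 3,4,5-trimethoxyphenyl to this smaller group does not yield a readable number. Among the compounds shown here, the one readable step is an at least 1.5-fold higher number from compound 1 to compound 4 (0.20 log units; that floor lies within the scatter). The steps from compound 2 and compound 3 to compound 4 cannot be read because all of these values are limits: the limit of > 100000 nM in this assay, at which 3 of the 4 values shown sit.

Compound 1, with 2-methylphenyl, remains the only compound shown with a number rather than a limit. From the compounds shown here alone, whether an amine or a carboxylic acid on this aryl ring would give a number remains open.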